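Urotensin-2 agonist series: trifluoromethyl to hydrogen step

The source may hold more compounds than are shown below. What is called first, only, known or untested is meant among the compounds shown, and "the series" means these compounds.

Three measured compounds share one core. Compound 1 `Cc1ccc(C(CCN(C)C)NC(=O)C#Cc2ccccc2)cc1` gives 131% in a functional assay on NIH3T3 cells for agonist activity at Urotensin-2 receptor (Homo sapiens), with a stated time of 5 days; a higher number here means a larger maximal response, a lower number a smaller maximal response. Compound 2 `COc1ccc(CCC(=O)NC(CCN(C)C)c2ccc3ccccc3c2)cc1` gives 113% in this assay. Compound 3 `CN(C)CCC(NC(=O)/C=C/c1ccc(C(F)(F)F)cc1)c1ccc2ccccc2c1` gives 117% in this assay, the second highest of the three numbers; it lies within the scatter of compound 2 and beyond the scatter only against compound 1. Compound 4 `CN(C)CCC(NC(=O)/C=C/c1ccccc1)c1ccc2ccccc2c1` differs from compound 3 by hydrogen in place of trifluoromethyl on an aromatic carbon, or, cut one bond further out, 4-(trifluoromethyl)phenyl to phenyl. For the measured compounds named here, no measured pair isolates this change, so the step is expected to be small, likely none beyond the scatter, with a slight downward lean. The estimated step of a number 5 percentage points lower from compound 3 to compound 4 (within the scatter) reflects that expectation. Compound 4 is expected to give about 112%, with a range from 95% to 130%.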

Compound 4, largest response reached (reported as efficacy), in percent of the reference or control that the assay uses: 116%
For compound 4 the middle estimate is 4 percentage points below the measured one; the range from low to high includes it.
By their numbers in this assay, from the lowest: compounds 2, 4 and 3 (each within the scatter of the next); then compound 1.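

In this assay, hydrogen in place of trifluoromethyl on an aromatic carbon, para to a large group, reads a number 1 percentage points lower from compound 3 to compound 4 (within the scatter). For the compounds shown here, this is the first pair that differs in one place, and it gives no sign that the maximal response depends on the trifluoromethyl group. No measured evidence bears on this result. Open, from the compounds shown here alone, is whether a nitrile, an amine or a carboxylic acid at this position would also stay within the scatter. Also open, going by these compounds, is whether the same step holds on the core of compound 1.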